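A Benzyl Group on the Sulfonamide Nitrogen of Compound 3

A few compounds are considered here, and "the series" means these few. Any claim that something is new, unique, unknown or untested is made for them only; others in the source may bear on it.

Compound 3 `COc1cc(NC(C)CCCNS(=O)(=O)c2ccc3ccccc3c2)c2ncccc2c1` stands at the edge of the numbers shown: in a functional assay on MDA-MB-435 cells (Homo sapiens) for cytotoxicity (on this read-out lower numbers stand for stronger inhibition and higher numbers for weaker inhibition), compound 3 gives > 10000 nM, which is a limit of the assay and not a number. Compound 1 `O=S(=O)(c1ccc2ccccc2c1)N(CCCCNc1ccnc2cc(Cl)ccc12)Cc1ccccc1` sits at the same limit, giving > 10000 nM in this assay. Compound 2 `O=S(=O)(c1ccc2ccccc2c1)N(CCCCCCNc1ccnc2cc(Cl)ccc12)Cc1ccccc1`, which also carries a benzyl group on its sulfonamide nitrogen, gives 1700 nM in this assay. The step to compound 4 `COc1cc(NC(C)CCCN(Cc2ccccc2)S(=O)(=O)c2ccc3ccccc3c2)c2ncccc2c1` places (benzyl in place of hydrogen on a sulfonamide nitrogen). Since compound 2 shows 1700 nM with that group present, the change from compound 3 is expected to bring a gain beyond the usual scatter. Yet two of the three values rest at the limit (the limit of > 10000 nM in this assay, at which 2 of the 3 values shown sit), so the gain is expected to be modest. Compound 4 is estimated at 6000 nM, between 1500 nM and 20000 nM, an expected step of an at least 1.6-fold lower number from compound 3 to compound 4 (0.22 log units; that floor lies within the scatter) in this assay.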

Compound 4, half-maximal inhibitory concentration: > 10000 nM
Compound 4 ended at the assay's limit; the forecaster's own chance of this, stated with the estimate: 40%; middle value at least 1.6-fold (0.22 log units) from the limit.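

Among the compounds shown here, compound 3 and compound 4 both sit at a limit in this assay and no step between them can be read: the limit of > 10000 nM in this assay, at which 3 of the 4 values shown sit.
The compounds shown leave open whether benzyl in place of hydrogen on the sulfonamide nitrogen changes the inhibition at all.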